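Bromo for Nitro on the Aryl Carbinol of Compound 1

The compounds below may be only part of what the source reports. "The series", "measured", "known", "first", "only" and "open" are said of these compounds alone.

Compound 1 `Cn1cncc1C(O)(c1ccc([N+](=O)[O-])cc1)c1cc2cc([N+](=O)[O-])cc(-c3ccccc3)c2o1`: 547 nM
Compound 2 `COc1cccc(-c2cc(C=O)cc3cc(C(O)(c4ccc(C#N)cc4)c4cncn4C)oc23)c1`: 15.2 nM

In a functional assay on QG-56 cells (Homo sapiens) for antiproliferative activity (a higher number here means a weaker inhibitor, a lower number a stronger inhibitor), compound 1 gives 547 nM, the higher of the two numbers shown. Going by the values given here, compound 2 gives 15.2 nM, a gap beyond the scatter, but the two structures differ in more than one place and no single step links them. Compound 3 `Cn1cncc1C(O)(c1ccc(Br)cc1)c1cc2cc([N+](=O)[O-])cc(-c3ccccc3)c2o1` differs from compound 1 in one place: bromo in place of nitro on an aromatic carbon. Among the compounds with values here, no measured pair shows this exchange, so in this assay the step is expected to be small, in no clear direction, and possibly within the scatter. Compound 3 is expected to give 400 nM, within 150 nM to 1200 nM, a step of a 1.4-fold lower number from compound 1 to compound 3 (0.14 log units; within the scatter).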

Compound 3, half-maximal inhibitory concentration: 1480 nM
Estimate against measurement, compound 3: 3.7-fold (0.57 log units) below, outside the stated range (above it).
By their numbers in this assay, from the lowest: compound 2; then compound 1; then compound 3.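

In this assay the exchange of 4-nitrophenyl to 4-bromophenyl gives a 2.7-fold higher number from compound 1 to compound 3 (0.43 log units; beyond the scatter) and is the only single-place step shown, so the group on this aromatic carbon, para to a large group, does affect the read-out. Of the two groups, nitro gives the lower number on this core. No measurement shown accounts for the step. From the compounds shown here alone, whether an amine or a carboxylic acid at this position would give a lower number than nitro remains open, and two groups cannot establish a trend.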